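Trifluoromethyl for Fluoro on the Aryl of Compound 1

The source may report more compounds than this note shows. Statements on the series, on what has been measured and on what is new or still open speak of the compounds shown alone.

Compound 1 `O=C(/C=C\Nc1ccc(F)cc1)c1nc(-c2ccc(F)cc2)n2ccccc12` is one of three compounds examined in a functional assay on MDA-MB-231 cells (Homo sapiens) for cytotoxicity, read by MTT assay, with a stated time of 48 h; on this read-out higher numbers stand for weaker inhibition and lower numbers for stronger inhibition. In this assay compound 1 gives 25100 nM. Compound 2 `COc1ccc(-c2nc(C(=O)/C=C\Nc3ccc4[nH]ccc4c3)c3ccccn23)cc1` gives 28700 nM in this assay, and the two numbers lie within the scatter of each other. Compound 3 `COc1ccc(N/C=C\C(=O)c2nc(-c3ccc(F)cc3)n3ccccc23)cc1` reaches only the limit of this assay, > 30000 nM. Within the data shown here, the single measured step, an at least 1.1-fold higher number from compound 1 to compound 3 (0.07 log units; that floor lies within the scatter), comes from methoxy in place of fluoro on an aromatic carbon, and its floor lies within the scatter; the limit of > 30000 nM in this assay, at which 1 of the 3 values shown sits, is where that value sits.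

Compound 4 `O=C(/C=C\Nc1ccc(F)cc1)c1nc(-c2ccc(C(F)(F)F)cc2)n2ccccc12` differs from compound 1 by trifluoromethyl in place of fluoro on an aromatic carbon. Among the measured compounds shown here, no measured step touches this place; the step to compound 3 alters a different group, and all three recorded values crowd near the upper edge of what this assay measures. On that basis a step of a 1.1-fold higher number from compound 1 to compound 4 (0.05 log units; within the scatter) is expected, which is to say none beyond the scatter, with a real chance that only a limit is returned. Compound 4 is therefore estimated at 28000 nM in this assay, within 12000 nM to 65000 nM.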

Compound 4, half-maximal inhibitory concentration: > 30000 nM
Compound 4: only a limit was reported; the forecaster's own chance of this, stated with the estimate: 40%; middle value at least 1.0-fold (0.02 log units) away from the limit.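

Trifluoromethyl in place of fluoro gives the first measured step at this position, an at least 1.1-fold higher number from compound 1 to compound 4 (0.07 log units; that floor lies within the scatter), and its floor tells nothing beyond the scatter. Compound 4 gives only a limit of the assay, > 30000 nM. This change at the 4-fluorophenyl group therefore ends at the same limit as the methoxy change at a different place, and the upper edge of this assay now holds as many of the compounds as the measured numbers do: the limit of > 30000 nM in this assay, at which 2 of the 4 values shown sit.

Going by these compounds, the true size of the step stays open, since a limit gives a floor and nothing more, so how much a larger group at this position matters cannot be told. On these data alone, whether an amine or a carboxylic acid in this position would return a measured number in this assay also stays open.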